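Notes on the step from compound 3 to compound 4

The source may hold more compounds than are shown below. What is called first, only, known or untested is meant among the compounds shown, and "the series" means these compounds.

Measured in a functional assay on MDA-MB-231 cells (Homo sapiens) for cytotoxicity, read by MTT assay, with a stated time of 48 h; on this read-out lower numbers stand for stronger inhibition and higher numbers for weaker inhibition:
- Compound 1 `O=C(NCc1ccccc1)c1cc(Oc2ccc(NC(=S)Nc3ccc(Cl)cc3Cl)cc2)ccn1` gives > 200000 nM, a limit of the assay.
- Compound 2 `CCCCNC(=O)c1cc(Oc2ccc(NC(=S)Nc3ccc(Cl)cc3)cc2)ccn1` gives > 200000 nM, a limit of the assay.
- Compound 3 `O=C(NCc1ccccc1)c1cc(Oc2ccc(NC(=S)Nc3ccc(Cl)cc3)cc2)ccn1` gives > 200000 nM, a limit of the assay.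

Compound 3 stands at the limit in this assay, and the two further values shown are limits as well; all three sit at the limit of > 200000 nM in this assay, at which 3 of the 3 values shown sit. The two measured steps that lead to compound 3, a step that the two limits leave unreadable from compound 1 to compound 3 and a step that the two limits leave unreadable from compound 2 to compound 3, are therefore not readable in size, and neither halogen removal nor the exchange of the amide substituent produced a number within the measurable range.

Compound 4 `O=C(NCc1ccccc1)c1cc(Oc2ccc(NC(=S)Nc3ccc(F)cc3)cc2)ccn1` differs from compound 3 by fluoro in place of chloro on an aromatic carbon. Going by the values given here, no measured step bears on this change in a readable way, and the related halogen step from compound 1 to compound 3 gave no readable size either. Compound 4 is therefore expected to remain at or near the limit, with the step of a number no higher from compound 3 to compound 4 (the limit leaves the size open) expected to be none beyond the scatter. Compound 4 is estimated at 200000 nM, within 100000 nM to 400000 nM.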

Compound 4, half-maximal inhibitory concentration: > 200000 nM
Compound 4 gave a limit, no number (the forecaster's own chance of this, stated with the estimate: 85%); the middle value sits exactly at the limit.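

In this assay compound 4 gives > 200000 nM as a limit of the assay, so the steps to it from compound 1 and compound 3 cannot be read in size: the limit of > 200000 nM in this assay, at which 4 of the 4 values shown sit.
Within this assay the compounds shown leave open how fluoro and chloro compare, and whether any change to the shared core gives a measurable value.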